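The source may report more compounds than this note shows. Statements on the series, on what has been measured and on what is new or still open speak of the compounds shown alone.

Compound 1 `CCOC(=O)C(COC(=O)c1ccccc1OC(C)=O)c1ccc(F)cc1`: > 0.01 ug/mL
Compound 2 `CCOC(=O)C(COC(=O)c1ccccc1)c1ccc(C(F)(F)F)cc1`: > 0.01 ug/mL

In a functional assay on HCT-116 cells (Homo sapiens) for cytotoxicity, read by MTT assay, with a stated time of 72 h (a higher number here means a weaker inhibitor, a lower number a stronger inhibitor), compound 2 is reported only as a limit, > 0.01 ug/mL. Among the compounds with values here, the series so far offers only (the limit of > 0.01 ug/mL in this assay, at which 2 of the 2 values shown sit), and no measured step.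

Compound 3 `CCOC(=O)C(COC(=O)c1ccccc1OC(C)=O)c1ccc(C(F)(F)F)cc1` follows from compound 2 by acetoxy in place of hydrogen on an aromatic carbon. Compound 1, which also carries the 2-acetoxyphenyl group, is likewise a limit, > 0.01 ug/mL.

The expected step that the limit leaves unreadable from compound 2 to compound 3 is no change beyond the scatter, with no direction expected. For compound 3 the estimated value is 0.015 ug/mL, with an expected range of 0.004 ug/mL to 0.06 ug/mL.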

Compound 3, half-maximal inhibitory concentration: > 0.01 ug/mL
Compound 3: a limit, no number (the forecaster's own chance of this, stated with the estimate: 70%); the middle value does not contradict the limit.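

Compound 3 is again only a limit, > 0.01 ug/mL, and its steps from compound 1 and compound 2 cannot be read: the limit of > 0.01 ug/mL in this assay, at which 3 of the 3 values shown sit.

The compounds shown leave open whether acetoxy in place of hydrogen, or trifluoromethyl in place of fluoro, changes cytotoxicity at all.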